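Acyl chain length across the amide series

The compounds below may be only part of what the source reports. "The series", "measured", "known", "first", "only" and "open" are said of these compounds alone.

Going by the values given here, compound 2 `CCCCCCCCCCCC(=O)N[C@@H](CO)C[C@@H](O)c1ccccc1` gives the only number in a functional assay on CHO cells (Cricetulus griseus) for inhibition; a lower number here means a stronger inhibitor, a higher number a weaker inhibitor: compound 2 gives 70 nM. Compound 1 `CCCCCCCCCCCCCCCC(=O)N[C@@H](CO)C[C@@H](O)c1ccccc1` gives only a limit in this assay, > 1000 nM. Compound 3 `CCCCCCCCCCCCCCCCCC(=O)N[C@@H](CO)C[C@@H](O)c1ccccc1` likewise gives only a limit in this assay, > 1000 nM. Both measured steps are large, an at least 14-fold lower number from compound 1 to compound 2 (1.15 log units; beyond the scatter) and an at least 14-fold higher number from compound 2 to compound 3 (1.15 log units; beyond the scatter), and each rests on (the limit of > 1000 nM in this assay, at which 2 of the 3 values shown sit). Compound 4 `CCCCCCCCCC(=O)N[C@@H](CO)C[C@@H](O)c1ccccc1` differs from compound 2 by hydrogen in place of ethyl on a saturated chain carbon, nine bonds along the chain from a carbonyl carbon. Among the compounds with values here, this continues the shortening seen between compound 1 and compound 2, but no measured step reaches below the chain of compound 2, so only a modest step beyond the scatter, if any, is expected, a 1.7-fold higher number from compound 2 to compound 4 (0.23 log units; within the scatter). Compound 4 is therefore expected at 120 nM, with a range from 25 nM to 600 nM.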

Compound 4, half-maximal inhibitory concentration: 300 nM
For compound 4 the middle estimate is 2.5-fold (0.40 log units) below the measured one; the measured number falls inside the stated range.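

Hydrogen in place of ethyl at this position gives a 4.3-fold higher number from compound 2 to compound 4 (0.63 log units; beyond the scatter) in this assay, so shortening the chain below that of compound 2 also weakens inhibition, and compound 2 is the strongest of the four. Compound 4 still keeps an advantage over the longer chains, with an at least 3.3-fold lower number from compound 3 to compound 4 (0.52 log units; beyond the scatter) and an at least 3.3-fold lower number from compound 1 to compound 4 (0.52 log units; beyond the scatter), though both steps rest on a limit: the limit of > 1000 nM in this assay, at which 2 of the 4 values shown sit.

Still open, going by these compounds, is how an octanoyl or a tetradecanoyl chain would read. On these data alone, the true distance of compound 1 and compound 3 from compound 2 also remains unknown.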